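Nitro in place of methyl on two related cores

A few compounds are considered here, and "the series" means these few. Any claim that something is new, unique, unknown or untested is made for them only; others in the source may bear on it.

Compound 1 `COc1cc(O)cc(O)c1C(=O)/C=C/c1ccc(C)cc1` — in a functional assay on HeLa cells (Homo sapiens) for inhibition, read by MTT assay, with a stated time of 72 h (on this read-out lower numbers stand for stronger inhibition and higher numbers for weaker inhibition), compound 1 gives only a limit, > 50000 nM.
Compound 2 `COc1cc(O)cc(O)c1C(=O)/C=C/c1ccc([N+](=O)[O-])cc1` — in this assay compound 2 likewise gives only a limit, > 50000 nM.
Among the measured compounds shown here, compound 3 `COc1cc(OC)c(C(=O)/C=C/c2ccc(C)cc2)c(OC)c1` — in this assay compound 3 gives 17000 nM, the one actual number in the set.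

From compound 1 to compound 2 the change is nitro in place of methyl on an aromatic carbon; the step it made, a step that the two limits leave unreadable from compound 1 to compound 2, cannot be read because both values sit at the limit of > 50000 nM in this assay, at which 2 of the 3 values shown sit. The difference between the core of compound 1 and the core of compound 3 is not broken down here. Compound 4 `COc1cc(OC)c(C(=O)/C=C/c2ccc([N+](=O)[O-])cc2)c(OC)c1` is not yet measured; from compound 3 to compound 4 the change is nitro in place of methyl on an aromatic carbon, the same change at the same place. The measured pair therefore gives no size for it. For compound 4 in this assay the step is estimated as a 1.1-fold lower number from compound 3 to compound 4 (0.05 log units; within the scatter), resting on compound 3 at 17000 nM and on no readable precedent. Compound 4 is thus expected at 15000 nM, between 5000 nM and 50000 nM.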

Compound 4, half-maximal inhibitory concentration: 8000 nM
Compound 4: middle estimate off by 1.9-fold (0.27 log units), on the high side; measured number inside the range.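

In this assay nitro in place of methyl makes a 2.1-fold lower number from compound 3 to compound 4 (0.33 log units; beyond the scatter) and this modest step is the only readable size for the change. On the core of compound 1 the same change cannot be read, as compound 1 and compound 2 each give only a limit and not a number: the limit of > 50000 nM in this assay, at which 2 of the 4 values shown sit. The step therefore shows what the change does on one core and does not show whether its size or direction carries over to the other.

Open, as far as these compounds go, is whether an amine or a carboxylic acid on the same aromatic carbon would shift the number as nitro does on the core of compound 3. Also open, from the compounds shown here alone, is whether any group on the core of compound 1 gives a number rather than a limit.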